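The source may hold more compounds than are shown below. What is called first, only, known or untested is meant among the compounds shown, and "the series" means these compounds.

Measured in a functional assay on CCRF-CEM cells (Homo sapiens) for cytotoxicity, in the absence of a further agent; a lower number here means a stronger inhibitor, a higher number a weaker inhibitor:
- compound 1 `Nc1nc(N)c(CCCNc2cc(F)ccc2[N+](=O)[O-])c(O)n1` gives > 100000 nM
- compound 2 `COC(=O)c1ccc(CN(CCCc2c(N)nc(N)nc2O)c2cc(F)c([N+](=O)[O-])cc2[N+](=O)[O-])cc1` gives 2500 nM
- compound 3 `COC(=O)c1ccc(CN(CCCc2c(N)nc(N)nc2O)c2ccc([N+](=O)[O-])c(F)c2F)cc1` gives 41000 nM

The entry for compound 1 is a limit of the assay and not an exact number. Of the two exact numbers, compound 3 stands higher at 41000 nM and compound 2 lower at 2500 nM, a gap beyond the usual scatter. Compound 3 is therefore the weaker inhibitor of that pair.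

Compound 4 `COC(=O)c1ccc(CN(CCCc2c(N)nc(N)nc2O)c2cc(F)ccc2[N+](=O)[O-])cc1` is still unmeasured. It keeps the rest of compound 3 and changes one piece, with 5-fluoro-2-nitrophenyl in place of 2,3-difluoro-4-nitrophenyl on an amine nitrogen. Among the measured compounds shown here, no two measured compounds differ in one place only, so no direct precedent exists for this change. Compound 1 also carries 5-fluoro-2-nitrophenyl, and its entry is the limit > 100000 nM. That gives little reason to expect a gain in strength. Compound 2 at 2500 nM lies far enough from compound 3 to keep the range wide.

In this assay no change beyond the scatter is expected. The estimated step is a 1.4-fold lower number from compound 3 to compound 4 (0.14 log units; within the scatter). For compound 4 the expected value is 30000 nM, with an estimated range from 8000 nM to 100000 nM.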

Compound 4, half-maximal inhibitory concentration: 45000 nM
Estimate against measurement, compound 4: 1.5-fold (0.18 log units) below, and the stated range covers the measured number.
By their numbers in this assay, from the lowest: compound 2; then compounds 3 and 4 (each within the scatter of the next). At a limit, above all of these: compound 1.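

In this assay, 5-fluoro-2-nitrophenyl in place of 2,3-difluoro-4-nitrophenyl on the amine nitrogen gives a 1.1-fold higher number from compound 3 to compound 4 (0.04 log units; within the scatter), so these two aryl groups cannot be told apart by this read-out. The nitro group that compound 2 carries and compound 4 lacks has a far larger effect: hydrogen in its place gives an 18-fold higher number from compound 2 to compound 4 (1.26 log units; beyond the scatter), which ties much of the strength of compound 2 to that single group. Adding 4-(methoxycarbonyl)benzyl on the nitrogen on an aromatic ring gives an at least 2.2-fold lower number from compound 1 to compound 4 (0.34 log units; beyond the scatter), but that step starts from a limit, so it shows only a minimum size: the limit of > 100000 nM in this assay, at which 1 of the 4 values shown sits.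

Going by these compounds, it remains open whether the large effect of the added nitro group depends on the rest of the ring, and whether a nitrile or a trifluoromethyl group on the same aromatic carbon would keep the strength of compound 2. On these data alone, the role of the methoxycarbonyl group is also open, and a free carboxylic acid or an amide in its place would test it.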